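A Chloro Added to the Fused Ring

A few compounds are considered here, and "the series" means these few. Any claim that something is new, unique, unknown or untested is made for them only; others in the source may bear on it.

Compound 1 `O[C@@H]1Cc2ccccc2N[C@H](c2ccccc2)C1` gives > 300000 nM in an ADME assay on THP-1 cells (Homo sapiens) for cytotoxicity, read by MTT assay, with a stated time of 72 h (on this read-out lower numbers stand for higher toxicity in this test and higher numbers for lower toxicity in this test), which is a limit of the test.
Compound 2 `O[C@@H]1Cc2ccccc2N[C@H](c2ccccc2Cl)C1` gives > 300000 nM in this assay, again a limit.
Compound 3 `O[C@@H]1Cc2ccccc2N[C@H](c2ccccc2F)C1` gives > 300000 nM in this assay, also a limit.

Compound 2 therefore stands at the upper edge of what this assay can report, and so do the two compounds measured beside it (the limit of > 300000 nM in this assay, at which 3 of the 3 values shown sit). Compound 4 `O[C@@H]1Cc2cc(Cl)ccc2N[C@H](c2ccccc2Cl)C1` differs from compound 2 by chloro in place of hydrogen on an aromatic carbon. The measured steps that touch compound 2 are a step that the two limits leave unreadable from compound 1 to compound 2 and a step that the two limits leave unreadable from compound 2 to compound 3, and the third measured step, a step that the two limits leave unreadable from compound 1 to compound 3, is of the same kind: at both ends only a limit was reached, so no size can be read from any of them. They carry no information about the direction or size of a step, and nothing suggests that adding a second chloro would push toxicity into the readable range. For compound 4 the expected step of a number no higher from compound 2 to compound 4 (the limit leaves the size open) is thus no step beyond the scatter, with the test most likely reporting only its limit again. Compound 4 is estimated at 300000 nM, with a range from 80000 nM to 300000 nM.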

Compound 4, half-maximal cytotoxic concentration: 75500 nM
Compound 4: the middle estimate sits 4.0-fold (0.60 log units) above what was measured, outside the stated range (below it).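

For the compounds shown here, this aromatic carbon of the fused system is the first place on the shared core where a change gives a readable result: in this assay chloro in place of hydrogen gives an at least 3.9-fold lower number from compound 2 to compound 4 (0.59 log units; beyond the scatter). A lower number stands for higher toxicity in this test, so this added chloro brings compound 4 into the range that can be read, whereas the steps among compound 1, compound 2 and compound 3, all made on the other ring, cannot be read. The real size of the step may be larger, since it starts from a limit: the limit of > 300000 nM in this assay, at which 3 of the 4 values shown sit.

The compounds shown leave open whether a methyl group or an amine on this same carbon would shift the number as chloro does. They also leave open whether this chloro has the same effect with fluoro or hydrogen on the other ring in place of chloro.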